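A Methyl Added to the Aromatic Ring of Compound 3

A few compounds are considered here, and "the series" means these few. Any claim that something is new, unique, unknown or untested is made for them only; others in the source may bear on it.

Compound 3 `CC1CCCN1C1CCN(c2ccc(NC(=O)NCc3cc(Cl)cc(Cl)c3)cc2)C1` gives 7.1 nM in an assay on CHO cells for displacement of a labelled ligand from histamine receptor H3 (Macaca mulatta), read by scintillation counting, with a stated time of 1 h (a higher number here means a weaker inhibitor, a lower number a stronger inhibitor), the lowest of the three numbers in hand. Compound 2 `Cc1cc(NC(=O)NCc2cccs2)ccc1N1CCC(N2CCCC2C)C1` gives 8.4 nM in this assay, within the scatter of compound 3, while compound 1 `Cc1cc(NC(=O)Nc2cc(Cl)cc(Cl)c2)ccc1N1CCC(N2CCCC2C)C1` gives 43 nM. Among the compounds with values here, the one directly compared step, a 5.1-fold lower number from compound 1 to compound 2 (0.71 log units; beyond the scatter), concerns the group on the amide-type nitrogen and does not touch the change at hand. Within the data shown here, compound 4 `Cc1cc(NC(=O)NCc2cc(Cl)cc(Cl)c2)ccc1N1CCC(N2CCCC2C)C1` differs from compound 3 by methyl in place of hydrogen on an aromatic carbon, a change that no measured pair isolates; compounds 1 and 2 carry this methyl and compound 3 does not. The step to compound 4 is therefore expected to be a 1.0-fold lower number from compound 3 to compound 4 (0.01 log units; within the scatter), nothing beyond the scatter. Compound 4 is estimated at 7 nM, between 3 nM and 17 nM.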

Compound 4, inhibition constant: 28.8 nM
The estimate for compound 4 lay 4.1-fold (0.61 log units) below the measured number, outside the stated range (above it).
By their numbers in this assay, from the lowest: compounds 3 and 2 (each within the scatter of the next); then compounds 4 and 1 (each within the scatter of the next).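

In this assay, within the data shown here, methyl in place of hydrogen on this aromatic carbon, ortho to a large group and meta to a large group, is not a silent change: a 4.1-fold higher number from compound 3 to compound 4 (0.61 log units; beyond the scatter) is the first measured step for it. With that methyl in place, a 3.4-fold higher number from compound 2 to compound 4 (0.54 log units; beyond the scatter) follows from 3,5-dichlorophenyl in place of thiophen-2-yl, while a 1.5-fold lower number from compound 1 to compound 4 (0.17 log units; within the scatter) follows from 3,5-dichlorobenzyl in place of 3,5-dichlorophenyl. Nothing at hand gives a reason for the step from hydrogen to methyl.

Going by these compounds, whether ethyl, methoxy or an amine on this same carbon would behave as methyl does stays open. So does the size of this step with other groups on the amide-type nitrogen.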